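Fluorophenyl for methoxyphenyl on the diaryl allylic amino acid

The compounds below may be only part of what the source reports. "The series", "measured", "known", "first", "only" and "open" are said of these compounds alone.

Compound 1 `COc1ccc(/C(=C/CC(N)C(=O)O)c2ccc(C(C)C)cc2)cc1` is the reference point here. In a functional assay for inhibition of sodium- and chloride-dependent glycine transporter 1 (Rattus norvegicus), with a stated time of 30 min, in the presence of a further agent that is not named here (a lower number here means a stronger inhibitor, a higher number a weaker inhibitor), compound 1 gives only a limit, > 10000 nM, not a number. That value sits at the limit of > 10000 nM in this assay, at which 1 of the 2 values shown sits. Compound 2 `NC(C/C=C(/c1ccc(-c2ccccc2)cc1)c1ccc(F)cc1F)C(=O)O` carries a different pair of aryl groups on the shared core; in this assay compound 2 gives 3400 nM. For the measured compounds named here, no step between compounds differing in one place has been measured, so the two values show only that compound 2 gives a number where compound 1 gives a limit.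

Compound 3 `CC(C)c1ccc(/C(=C\CC(N)C(=O)O)c2ccccc2F)cc1` is the next compound, differing from compound 1 in one place: 2-fluorophenyl in place of 4-methoxyphenyl on a double-bonded chain carbon bound to an aromatic carbon and a double-bonded chain carbon. With compound 1 at a limit, the size of the step cannot be anchored. The step is expected to be an at least 1.2-fold lower number from compound 1 to compound 3 (0.09 log units; that floor lies within the scatter), toward stronger inhibition, small and uncertain. Compound 3 is estimated at 8000 nM, within 2000 nM to 30000 nM.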

Compound 3, half-maximal inhibitory concentration: 8020 nM
Compound 3: the middle estimate sits 1.0-fold (0.00 log units) below what was measured; the range from low to high includes it.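

Fluorine in the series: the 2-fluorophenyl group on a double-bonded chain carbon bound to an aromatic carbon and a double-bonded chain carbon, in place of 4-methoxyphenyl, gives the only single-place step shown in this assay: an at least 1.2-fold lower number from compound 1 to compound 3 (0.09 log units; that floor lies within the scatter). This step shows that a compound carrying the isopropylphenyl group of compound 1 can return a number in this assay, although the step is only a floor. Compound 1 gives > 10000 nM, a limit and not a number, so the true size of the step stays unknown: the limit of > 10000 nM in this assay, at which 1 of the 3 values shown sits.

Going by these compounds, it remains open whether the step follows from the entering fluorine or from the departing methoxy group, and a plain phenyl at this carbon would separate the two. On these data alone, the effect of 4-fluorophenyl or 2-chlorophenyl at the same carbon is also open.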